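A few compounds are considered here, and "the series" means these few. Any claim that something is new, unique, unknown or untested is made for them only; others in the source may bear on it.

Of the compounds shown here, two built on one shared core have so far been tested in an ADME assay on BHK-21 cells (Mesocricetus auratus) for cytotoxicity, read by MTT assay, with a stated time of 72 h; a higher number here means that more compound is tolerated, a lower number that less compound is tolerated. Compound 1 (`NS(=O)(=O)c1ccc(N2N=C(c3ccccc3)CC2c2ccccc2F)cc1`) gives 21000 nM in this test, and compound 2 (`NS(=O)(=O)c1ccc(N2N=C(c3ccc(OCc4ccccc4)cc3)CC2c2ccc(F)cc2)cc1`) gives 60000 nM, the higher of the two numbers. The gap between them lies beyond the scatter, but the two compounds differ in more than one place, so it cannot be tied to any single change. Compound 3 (`Cc1cccc(C2CC(c3ccc(OCc4ccccc4)cc3)=NN2c2ccc(S(N)(=O)=O)cc2)c1`) carries 3-methylphenyl in place of 4-fluorophenyl on a saturated ring carbon of compound 2 (3-methylphenyl in place of 4-fluorophenyl on a saturated ring carbon) and is otherwise identical. Among the measured compounds shown here, no measured pair isolates this exchange, so the size of the step must be judged from the structures alone. Going by these compounds, the group that enters and the group that leaves are both a single six-membered aromatic ring of carbon only, so no step beyond the scatter is expected, and the direction remains open. The expected change is a 1.3-fold lower number from compound 2 to compound 3 (0.10 log units; within the scatter), which would stay within the scatter. For compound 3 the estimated value is 48000 nM, with an expected range from 20000 nM to 100000 nM in this assay.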

Compound 3, half-maximal cytotoxic concentration: 8000 nM
Compound 3: the middle estimate sits 6.0-fold (0.78 log units) above what was measured, and the stated range ends above it.
By their numbers in this assay, from the lowest: compound 3; then compound 1; then compound 2.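

In this assay, putting 3-methylphenyl in place of 4-fluorophenyl on the saturated ring carbon gives a 7.5-fold lower number from compound 2 to compound 3 (0.88 log units; beyond the scatter), so the number in this test does respond to the group at this position, a point the earlier pair, which differs in more than one place, could not settle. The step also shows that a close match in what can be counted does not guarantee a small change: both groups have 7 heavy atoms and one six-membered aromatic ring of carbon only, with no hydrogen-bond donors or acceptors and no net charge. Nothing measured here accounts for the size of this step.

The exchange alters both the substituent on the aromatic ring and its place, and the compounds shown cannot tell which of the two matters, since a 4-methylphenyl or a 3-fluorophenyl group at this carbon would be needed to separate them. Going by these compounds, it also remains open whether the step would be the same with other parts of the molecule changed, or how an unsubstituted phenyl group at this carbon would compare.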